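A few compounds are considered here, and "the series" means these few. Any claim that something is new, unique, unknown or untested is made for them only; others in the source may bear on it.

Three compounds sharing one core have been examined in a functional assay on PC-3 cells (Homo sapiens) for cytotoxicity, read by MTT assay, with a stated time of 72 h; on this read-out lower numbers stand for stronger inhibition and higher numbers for weaker inhibition. For compound 1 `CNC(=O)c1cc(Oc2ccc(C(=O)/C=C/c3ccco3)cc2)ccn1` there is no number, and its result stands as "not determined" (no result reported). Compound 2 `CNC(=O)c1cc(Oc2ccc(C(=O)/C=C/c3ccc(Br)cc3)cc2)ccn1` gives 18500 nM, and compound 3 `CNC(=O)c1cc(Oc2ccc(C(=O)/C=C/c3ccc(C#N)cc3)cc2)ccn1` gives 3870 nM, the lower of the two numbers available. Compound 4 `CNC(=O)c1cc(Oc2ccc(C(=O)/C=C/c3ccccc3)cc2)ccn1` still awaits a result. The change is hydrogen in place of cyano on an aromatic carbon, which means hydrogen in place of cyano on an aromatic carbon, para to a large group. Among the measured compounds shown here, the only measured step at this place is a 4.8-fold lower number from compound 2 to compound 3 (0.68 log units; beyond the scatter), a modest one with cyano in place of bromo. A step of similar size towards a higher number is therefore expected, though a single step is thin evidence. For compound 4 the estimated value is 8000 nM, with an expected range from 2500 nM to 25000 nM. The expected step is a 2.1-fold higher number from compound 3 to compound 4 (0.32 log units; beyond the scatter).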

Compound 4, half-maximal inhibitory concentration: 3170 nM
Compound 4: middle estimate off by 2.5-fold (0.40 log units), on the high side; low and high end bracket the measured number.
By their numbers in this assay, from the lowest: compounds 4 and 3 (each within the scatter of the next); then compound 2.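

In this assay, replacing cyano with hydrogen gives a 1.2-fold lower number from compound 3 to compound 4 (0.09 log units; within the scatter), so these two groups cannot be told apart at this place on the ring. Bromo now stands alone, with a 5.8-fold lower number from compound 2 to compound 4 (0.77 log units; beyond the scatter), which suggests that the earlier step from bromo to cyano reflects weaker inhibition with bromo, not a gain from cyano. Nothing available here explains why bromo differs. As far as these compounds go, whether an amine or a methoxy group at this place would match hydrogen or bromo remains open.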